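Swapping a Methoxyphenyl for a Dichlorophenyl

A few compounds are considered here, and "the series" means these few. Any claim that something is new, unique, unknown or untested is made for them only; others in the source may bear on it.

In a functional assay on HT-1080 cells (Homo sapiens) for cytotoxicity, read by MTT assay, with a stated time of 72 h (on this read-out higher numbers stand for weaker inhibition and lower numbers for stronger inhibition), compound 3 (`COc1ccccc1/C=C1\CCC/C(=C\c2ccc(OC)c(OC)c2)C1=O`) gives 8100 nM. That lies within the scatter of compound 2 (`COc1ccc(/C=C2\CCC/C(=C\c3cccc(OC)c3OC)C2=O)cc1OC`) at 6400 nM and of compound 1 (`COc1cccc(/C=C2\CCC/C(=C\c3ccccc3Cl)C2=O)c1OC`) at 11700 nM. Compound 4 (`COc1ccc(/C=C2\CCC/C(=C\c3cc(Cl)cc(Cl)c3)C2=O)cc1OC`) differs from compound 3 as follows: 3,5-dichlorophenyl in place of 2-methoxyphenyl on a double-bonded chain carbon bound to a double-bonded ring carbon. Within the data shown here, the only measured step, a 1.3-fold higher number from compound 2 to compound 3 (0.10 log units; within the scatter), swaps hydrogen for methoxy on an aromatic carbon and stays within the scatter. Among the measured compounds shown here, compound 1, the only measured compound with chlorine on an aromatic ring, gives 11700 nM. For the measured compounds named here, no measured step covers a change this large, so the expectation is loose. The expected step, a 1.1-fold lower number from compound 3 to compound 4 (0.03 log units; within the scatter), is none beyond the scatter. For compound 4 the estimated value is 7500 nM, with an expected range of 3000 nM to 18000 nM.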

Compound 4, half-maximal inhibitory concentration: 3000 nM
For compound 4 the middle estimate is 2.5-fold (0.40 log units) above the measured one; the range from low to high includes it.
By their numbers in this assay, from the lowest: compound 4; then compounds 2, 3 and 1 (each within the scatter of the next).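

Among these compounds, replacing 2-methoxyphenyl with 3,5-dichlorophenyl on a double-bonded chain carbon bound to a double-bonded ring carbon gives the first step beyond the scatter in this assay, with a 2.7-fold lower number from compound 3 to compound 4 (0.43 log units; beyond the scatter) as a modest gain in inhibition. The group at this place can therefore shift the result, which the earlier step could not show. Nothing available explains this gain.

From the compounds shown here alone, this single step adds chlorines and removes a methoxy together, so their separate contributions remain unknown. A 3,5-dimethylphenyl or an aminophenyl group at this place would help to separate them.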